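Formylphenyl for methylphenyl on a benzyl-bearing core

This account rests on a few compounds, and the source may have more. Where it says the series, first, only, none or still open, it means among the compounds named here.

For the measured compounds named here, the two compounds measured so far were read in a functional assay on RXF 393 cells (Homo sapiens) for inhibition, read by sulforhodamine B assay, with a stated time of 48 h, tested at 10 uM; on this read-out lower numbers stand for less inhibition and higher numbers for more inhibition at the one concentration tested (going by the name of the read-out). Compound 1 `O=Cc1ccc(-c2cn3ccnc3c(-c3ccc4ncn(C5CCCCC5)c4c3)n2)cc1` gives 25% in this assay. Compound 2 `Cc1cccc(-c2cn3ccnc3c(-c3ccc4ncn(Cc5ccccc5)c4c3)n2)c1` gives 2.01% in this assay, which is the lowest of the two numbers available; the nearest number, that of compound 1, stands higher by a margin beyond the usual scatter.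

Compound 3 `O=Cc1ccc(-c2cn3ccnc3c(-c3ccc4ncn(Cc5ccccc5)c4c3)n2)cc1` has not yet been measured. Relative to compound 2 its structure differs in one place: 4-formylphenyl in place of 3-methylphenyl on an aromatic carbon. The 4-formylphenyl that enters is the same group that compound 1 carries, while the remainder of compound 3 matches compound 2.

Going by the values given here, no pair of measured compounds differs in just one place, so no step is known that isolates this change. Compound 1, with its value of 25%, shows that a 4-formylphenyl is compatible with more inhibition than compound 2 displays, although compound 1 also differs elsewhere. For compound 3 a rise beyond the scatter is therefore expected, a number 18 percentage points higher from compound 2 to compound 3 (beyond the scatter). Compound 3 is estimated at 20%, within a range from 5% to 40%.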

Compound 3, a percentage reported as inhibition, at one concentration (the size of the read-out at that concentration, not a potency): 25%
Beside the measured number, compound 3's estimate is 5 percentage points below it, within the range that was stated.
By their numbers in this assay, from the lowest: compound 2; then compounds 1 and 3 (each within the scatter of the next).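

In this assay, for the compounds shown here, with the benzyl on the aromatic nitrogen held fixed, 4-formylphenyl in place of 3-methylphenyl on the aromatic carbon gives a number 23 percentage points higher from compound 2 to compound 3 (beyond the scatter), the first step to show that the number responds to a change at this position of the shared core. With the 4-formylphenyl held fixed, benzyl in place of cyclohexyl on the aromatic nitrogen gives no change at the digits printed from compound 1 to compound 3 (within the scatter), so this read-out does not separate these two groups when they are tested in this pair. Nothing measured here accounts for the rise seen with the 4-formylphenyl.

The step from the 3-methylphenyl changes both the substituent and its place on the phenyl ring, and the compounds shown do not separate these two parts of the change. They also leave open what happens at this position when a carboxylic acid or an amine takes the place of the formyl group on the phenyl ring, and whether benzyl and cyclohexyl would still give matching numbers with the 3-methylphenyl in place.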